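Dropping the ethyl from compound 2: cytotoxicity on MT4 cells

The compounds below may be only part of what the source reports. "The series", "measured", "known", "first", "only" and "open" are said of these compounds alone.

The measured compounds:
Compound 1, `CNc1nc(Nc2ccc(C#N)cc2)nc(Oc2cccc3ccccc23)n1`, gives 30300 nM in an ADME assay on MT4 cells (Homo sapiens) for cytotoxicity, read by MTT assay, with a stated time of 4 days; a lower number here means that less compound is tolerated, a higher number that more compound is tolerated.
Compound 2, `CCNc1nc(Nc2ccc(C#N)cc2)nc(Oc2ccc3cc(Br)ccc3c2Br)n1`, gives 74400 nM in this assay.

Compound 2 stands at the higher of the two numbers in this assay; compound 1 is its nearest neighbour, and the gap between them is beyond the usual scatter of repeated measurements. For the measured compounds named here, no pair of measured compounds differs in only one place, so no single step of known size can be taken from these data.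

Compound 3, `N#Cc1ccc(Nc2nc(N)nc(Oc3ccc4cc(Br)ccc4c3Br)n2)cc1`, is compound 2 with one change: hydrogen in place of ethyl on a nitrogen on an aromatic ring. This is the smallest kind of change that can be made here, and nothing in the measured pair speaks to it, since compounds 1 and 2 differ in several places at once. The expected step from compound 2 to compound 3 in this assay is therefore a 1.2-fold lower number from compound 2 to compound 3 (0.09 log units; within the scatter), with no direction beyond the scatter. Compound 3 is estimated to give 60000 nM in this assay, with a range from 25000 nM to 150000 nM.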

Compound 3, half-maximal cytotoxic concentration: 244000 nM
For compound 3 the middle estimate is 4.1-fold (0.61 log units) below the measured one; measured number above the stated range.
By their numbers in this assay, from the lowest: compound 1; then compound 2; then compound 3.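

For the compounds shown here, compound 2 and compound 3 form the first measured pair that differs in only one place, so the change from ethylamino to amino can now be read on its own in this assay, where the step is a 3.3-fold higher number from compound 2 to compound 3 (0.52 log units; beyond the scatter), a modest one that lies beyond the scatter. Hydrogen in place of ethyl on this nitrogen therefore moves the number towards more compound being tolerated, which shows that the read-out responds to what sits at this position and that the ethyl is not required for the tolerance seen with compound 2. Nothing among the data shown offers an explanation for this step.

What the compounds shown leave open is how other groups on this nitrogen would stand against ethyl and hydrogen on the same core, for instance a methyl, a longer chain such as propyl, or a hydroxyethyl group. Also open, as far as these compounds go, is whether the same change would give a step of similar size and direction on the core of compound 1, which differs from compound 2 in several places at once.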